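This account rests on a few compounds, and the source may have more. Where it says the series, first, only, none or still open, it means among the compounds named here.

Of the compounds shown here, two sharing one core have been tested in a functional assay on aorta (Rattus norvegicus) for inhibition; on this read-out higher numbers stand for an effect only at larger amounts of compound and lower numbers for an effect already at smaller amounts. Compound 1 `CCCNC1=NS(=O)(=O)c2cccc(Cl)c2N1` gives 180000 nM in this assay. Among the compounds with values here, compound 2 `CCCNC1=NS(=O)(=O)c2ccc(Cl)cc2N1` gives 73200 nM in this assay, the lowest of the two numbers; its only neighbour is compound 1, whose higher number lies beyond the scatter. Compound 3 `O=S1(=O)N=C(NC2CCC2)Nc2cc(Cl)ccc21` has not yet been measured. It differs from compound 2 in one place: cyclobutyl in place of propyl on an amine nitrogen. Within the data shown here, no comparable step has been measured, so the expected step from compound 2 to compound 3 is a 1.3-fold lower number from compound 2 to compound 3 (0.12 log units; within the scatter), which stays within the scatter. Compound 3 is accordingly estimated at 55000 nM, in a range from 20000 nM to 150000 nM.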

Compound 3, half-maximal effective concentration: > 300000 nM
Compound 3 was reported as a limit (the forecaster's own chance of this, stated with the estimate: 10%); middle value at least 5.4-fold (0.73 log units) from the limit.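

In this assay compound 3 gives > 300000 nM, which is a limit of the assay and not a number. Within the data shown here, replacing propyl with cyclobutyl on the amine nitrogen gives an at least 4.0-fold higher number from compound 2 to compound 3 (0.61 log units; beyond the scatter), the first measured step at this position, and it shows that this small change can cost much of the effect. The true size of the step stays unknown, since it rests on a limit: the limit of > 300000 nM in this assay, at which 1 of the 3 values shown sits.

The compounds shown leave open whether the ring or the extra carbon accounts for this loss. A butyl chain or a cyclopropyl ring on the same nitrogen would help separate the two.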